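The source may hold more compounds than are shown below. What is called first, only, known or untested is meant among the compounds shown, and "the series" means these compounds.

Compound 1 `Oc1cccc(-c2cc(-c3ccccc3F)cc(-c3cccc(O)c3)n2)c1` and compound 2 `Oc1cccc(-c2cc(-c3ccc(F)cc3)cc(-c3cccc(O)c3)n2)c1` share one core and differ only in the fluorophenyl group. In a functional assay on HCT-15 cells (Homo sapiens) for inhibition (on this read-out higher numbers stand for weaker inhibition and lower numbers for stronger inhibition), compound 1 gives 5300 nM; compound 2 gives 6310 nM. The step of a 1.2-fold higher number from compound 1 to compound 2 (0.08 log units; within the scatter) lies within the scatter, so compound 2 and compound 1 stand at one level on the two numbers in hand, and neither can be ranked against the other.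

Compound 3 `Oc1cccc(-c2cc(-c3ccc(OC(F)(F)F)cc3)cc(-c3cccc(O)c3)n2)c1` is not yet measured. It carries trifluoromethoxy in place of fluoro on an aromatic carbon. Among the compounds with values here, no measured step exchanges fluoro for trifluoromethoxy; the only step available, a 1.2-fold higher number from compound 1 to compound 2 (0.08 log units; within the scatter), bears on it just by showing that the fluorophenyl ring accepts a move of the fluoro group without a change beyond the scatter. On that basis the step from compound 2 to compound 3 is expected to be a 1.0-fold lower number from compound 2 to compound 3 (0.00 log units; within the scatter), not beyond the scatter in either direction. Compound 3 is estimated at 6300 nM, with a range from 2500 nM to 16000 nM.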

Compound 3, half-maximal inhibitory concentration: > 50000 nM
Compound 3 gave a limit, no number (the forecaster's own chance of this, stated with the estimate: 5%); middle value at least 7.9-fold (0.89 log units) from the limit.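

In this assay, within the data shown here, the earlier pair showed only that moving the fluoro group on the ring caused no change beyond the scatter. Replacing fluoro with trifluoromethoxy at the place para to a large group gives an at least 7.9-fold higher number from compound 2 to compound 3 (0.89 log units; beyond the scatter), which means weaker inhibition, so this position is not indifferent to the group it carries. Compound 3 stands at a limit of the assay, not at a number: the limit of > 50000 nM in this assay, at which 1 of the 3 values shown sits.

The compounds shown leave open whether the loss is particular to trifluoromethoxy or also appears with other groups at this place, such as methoxy, an amine or a carboxylic acid. They also leave open how far compound 3 lies past its limit and whether trifluoromethoxy would have the same result at the fluoro position of compound 1.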